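The source may hold more compounds than are shown below. What is called first, only, known or untested is meant among the compounds shown, and "the series" means these compounds.

Compound 1 `CCCCCCCCCCn1cc(/C=[N+](\[O-])c2ccccc2)nn1` in a functional assay on COLO 205 cells (Homo sapiens) for inhibition, read by MTT assay, with a stated time of 24 h (on this read-out lower numbers stand for stronger inhibition and higher numbers for weaker inhibition), gives > 100000 nM, which is a limit of the assay rather than a number. Compound 2 `CCCCCCCCCCn1cc(/C=[N+](\[O-])Cc2ccccc2)nn1` in this assay gives > 100000 nM, again a limit rather than a number. Compound 3 `CCCCCCCCn1cc(/C=[N+](\[O-])C(C)(C)C)nn1` in this assay gives 30800 nM.

Among the three, compound 3 is the only one with an actual number; the other two sit at the limit of > 100000 nM in this assay, at which 2 of the 3 values shown sit. The step that the two limits leave unreadable from compound 1 to compound 2 can therefore not be read. Compound 4 `CCCCCCCCCCn1cc(/C=[N+](\[O-])C(C)(C)C)nn1` differs from compound 3 by ethyl in place of hydrogen on a saturated chain carbon, eight bonds along the chain from an aromatic nitrogen. Going by the values given here, no measured step touches this part of the molecule: the one measured step changes the group on the double-bonded nitrogen, and its size is not readable. The data thus give no guide to whether a longer chain helps or hurts, and the step is expected to be small, about a 1.0-fold lower number from compound 3 to compound 4 (0.01 log units; within the scatter), within the scatter in either direction. Compound 4 is estimated at 30000 nM, with a likely range from 8000 nM to 120000 nM.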

Compound 4, half-maximal inhibitory concentration: 22100 nM
Compound 4: middle estimate off by 1.4-fold (0.13 log units), on the high side, within the range that was stated.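

Keeping the tert-butyl group on the double-bonded nitrogen and adding ethyl in place of hydrogen on the chain gives a 1.4-fold lower number from compound 3 to compound 4 (0.14 log units; within the scatter) in this assay, so at this chain position the two values cannot be told apart. With the chain held the same, the group on the double-bonded nitrogen now shows a readable effect: tert-butyl in place of benzyl gives an at least 4.5-fold lower number from compound 2 to compound 4 (0.65 log units; beyond the scatter), and tert-butyl in place of phenyl gives an at least 4.5-fold lower number from compound 1 to compound 4 (0.65 log units; beyond the scatter). As far as these compounds go, the true sizes of these two steps remain unknown, since compound 1 and compound 2 each stand at a limit of the assay rather than at a number: the limit of > 100000 nM in this assay, at which 2 of the 4 values shown sit.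

The step between phenyl and benzyl still cannot be read. Also open, from the compounds shown here alone, are whether a smaller group such as isopropyl on the double-bonded nitrogen would keep the activity seen with tert-butyl, and whether a shorter butyl chain or an amine at the chain's end would shift the value.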